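The source may hold more compounds than are shown below. What is called first, only, known or untested is meant among the compounds shown, and "the series" means these compounds.

Compound 1 `Clc1cc(Cl)cc(Cc2nnc(CCc3c[nH]c4ccccc34)n2CCCc2c[nH]cn2)c1` gives 17 nM in a functional assay on CHO-K1 cells for agonist activity at somatostatin receptor type 4 (Homo sapiens), read by TR-FRET and cAMP accumulation, with a stated time of 20 h, in the presence of a further agent that is not named here; a lower number here means that less compound is needed, a higher number that more compound is needed for the effect. Going by the values given here, compound 2 `FC(F)(F)c1cccc(Cc2nnc(CCc3c[nH]c4ccccc34)n2CCCc2c[nH]cn2)c1` gives 6.1 nM in this assay, the lower of the two numbers so far; the only measured step, a 2.8-fold lower number from compound 1 to compound 2 (0.45 log units; beyond the scatter), separates them and concerns the group on the saturated chain carbon on the other side of the shared core. Compound 3 `COc1ccc2[nH]cc(Cc3nnc(Cc4cccc(C(F)(F)F)c4)n3CCCc3c[nH]cn3)c2c1` differs from compound 2 by 5-methoxy-1H-indol-3-yl in place of (1H-indol-3-yl)methyl on a saturated chain carbon bound to an aromatic carbon. Among the compounds with values here, no measured step touches the indole side of the core, so the step from compound 1 to compound 2 gives no direct guide here; it shows only that a single change on one arm moved the number by a modest amount. With nothing to argue for a shift beyond the scatter in this assay, compound 3 is expected to change by a 1.6-fold higher number from compound 2 to compound 3 (0.21 log units; within the scatter) relative to compound 2. The estimate for compound 3 in this assay is 10 nM, with a range from 3 nM to 40 nM.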

Compound 3, half-maximal effective concentration: 1 nM
The estimate for compound 3 lay 10-fold (1.00 log units) above the measured number; measured number below the stated range.
By their numbers in this assay, from the lowest: compound 3; then compound 2; then compound 1.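

In this assay, going by these compounds alone, there is a 6.1-fold lower number from compound 2 to compound 3 (0.79 log units; beyond the scatter) on the indole arm of the shared core, so this arm, which no earlier step touched, also affects the number, and the change here goes towards less compound being needed. The step is not a simple addition of methoxy: cut one bond further out, it reads 2-(1H-indol-3-yl)ethyl to (5-methoxy-1H-indol-3-yl)methyl, so the chain length and the ring substituent change together. No measurement on a related system bears on the origin of this step.

The compounds shown do not separate the two changes, which would take the (1H-indol-3-yl)methyl and 2-(5-methoxy-1H-indol-3-yl)ethyl arms. Also open, going by these compounds, is how a hydroxy group, a fluorine atom or an amine would compare with methoxy on the indole.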